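Dienone in Place of Hydroxylated Ring on a Glucoside

The compounds below may be only part of what the source reports. "The series", "measured", "known", "first", "only" and "open" are said of these compounds alone.

compound 1, `O=C(/C=C/C1(O)C=CC(O)CC1=O)OC[C@H]1O[C@@H](Oc2ccc(O)cc2)[C@H](O)[C@@H](O)[C@@H]1O`: > 690000 nM
compound 2, `O=C1C=CC(O)(/C=C/C(=O)OC[C@H]2O[C@@H](Oc3ccc(O)cc3)[C@H](OC(=O)/C=C/CC3(O)C=CC(=O)C=C3)[C@@H](O)[C@@H]2O)C=C1`: 161000 nM

In an ADME assay on HEK293 cells (Homo sapiens) for cytotoxicity, read by resazurin assay, with a stated time of 72 h (a higher number here means a weaker inhibitor, a lower number a stronger inhibitor), compound 1 gives > 690000 nM, which is a limit of the assay and not a number. Compound 1 therefore stands only at the limit of > 690000 nM in this assay, at which 1 of the 2 values shown sits. In this assay compound 2 gives 161000 nM. Compound 3, `O=C1C=CC(O)(/C=C/C(=O)OC[C@H]2O[C@@H](Oc3ccc(O)cc3)[C@H](O)[C@@H](O)[C@@H]2O)C=C1`, differs from compound 1 by a group of 8 heavy atoms (6 carbon, 2 oxygen; one six-membered non-aromatic ring of carbon only) in place of a group of 9 heavy atoms (6 carbon, 3 oxygen; one six-membered non-aromatic ring of carbon only), on a double-bonded chain carbon bound to a double-bonded chain carbon. Among the compounds with values here, no measured step of this kind exists, so the expected step in this assay is a small move toward a stronger inhibitor, hardly beyond the scatter. Compound 3 is estimated at 400000 nM, between 150000 nM and 1000000 nM. The expected step is an at least 1.7-fold lower number from compound 1 to compound 3 (0.23 log units; that floor lies within the scatter).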

Compound 3, half-maximal inhibitory concentration: 195000 nM
Beside the measured number, compound 3's estimate is 2.1-fold (0.31 log units) above it; measured number inside the range.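

In this assay, the group of 8 heavy atoms with 3 double bonds outside aromatic rings, in place of the group of 9 heavy atoms, gives an at least 3.5-fold lower number from compound 1 to compound 3 (0.54 log units; beyond the scatter). Within the data shown here, this is the only step read at this place, on a double-bonded chain carbon bound to a double-bonded chain carbon, and it shows that this change lowers the number beyond the scatter. Its full size cannot be read, and the step is only a floor, as compound 1 stands at a limit of the assay: the limit of > 690000 nM in this assay, at which 1 of the 3 values shown sits.

The compounds shown leave open how a six-membered ring carrying an amine or a carboxylic acid would fare at this place. They also leave open whether a longer chain there would move the number further.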